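Side-chain variation on a shared core: working notes

The compounds below may be only part of what the source reports. "The series", "measured", "known", "first", "only" and "open" are said of these compounds alone.

All numbers below come from a functional assay on cells for antagonist activity at C-X-C chemokine receptor type 4 (Homo sapiens), read by fluorescence and calcium flux, with stated times of 25 min and 90 s; a lower number here means a stronger inhibitor, a higher number a weaker inhibitor.

Compound 1 `c1cncc(CNCCCCN(C[C@H]2Cc3ccccc3CN2)[C@H]2CCCc3cccnc32)c1` gives 15.3 nM.
Compound 2 `c1ccc2c(c1)CN[C@@H](CN(CCCCNCC1CCNCC1)[C@H]1CCCc3cccnc31)C2` gives 36.5 nM.
Compound 3 `c1ccc2c(c1)CN[C@@H](CN(CCCCNC1CCOCC1)[C@H]1CCCc3cccnc31)C2` gives 29.4 nM.

Compound 1 carries the lowest number of the three. Its nearest neighbour is compound 3, within the scatter; compound 2 sits furthest, with a 2.4-fold higher number from compound 1 to compound 2 (0.38 log units; beyond the scatter), a modest step. Between compound 2 and compound 3 the step of a 1.2-fold lower number from compound 2 to compound 3 (0.09 log units; within the scatter) is within the scatter, so swapping the terminal group at the distal amine has so far cost little.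

Compound 4 `CC(C)(CCN)CN(C[C@H]1Cc2ccccc2CN1)[C@H]1CCCc2cccnc21` is not yet measured. It differs from compound 1 by a group of 6 heavy atoms (5 carbon, 1 nitrogen; no ring) in place of a group of 11 heavy atoms (9 carbon, 2 nitrogen; one six-membered aromatic ring with 1 hetero atom), on a saturated chain carbon bound to an amine nitrogen. The measured steps bear on it only loosely: they replaced one terminal group by another, whereas here the ring is gone and the chain is shortened. Because the steps of a 2.4-fold higher number from compound 1 to compound 2 (0.38 log units; beyond the scatter) and a 1.9-fold higher number from compound 1 to compound 3 (0.28 log units; within the scatter) stayed modest, a loss beyond the scatter but not a large one is expected, giving an estimated 3.9-fold higher number from compound 1 to compound 4 (0.59 log units; beyond the scatter). Compound 4 is therefore estimated at 60 nM, range 20 nM to 200 nM.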

Compound 4, half-maximal inhibitory concentration: > 33300 nM
Compound 4: only a limit was reported; the forecaster's own chance of this, stated with the estimate: 5%; at least 550-fold (2.74 log units) between middle value and limit.
By their numbers in this assay, from the lowest: compounds 1, 3 and 2 (each within the scatter of the next, the first and the last beyond it). At a limit, above all of these: compound 4.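

Compound 4 is reported only as a limit, not as a number: the limit of > 33300 nM in this assay, at which 1 of the 4 values shown sits. At this saturated chain carbon bound to an amine nitrogen, replacing the ring-bearing groups with a group that has no ring gives an at least 2100-fold higher number from compound 1 to compound 4 (3.33 log units; beyond the scatter), an at least 1100-fold higher number from compound 3 to compound 4 (3.05 log units; beyond the scatter) and an at least 910-fold higher number from compound 2 to compound 4 (2.96 log units; beyond the scatter), each large. Going by these compounds alone, the earlier steps, modest or within the scatter, showed only that one ring-bearing terminal group could replace another; this result shows that the position is far from indifferent to every change.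

The compounds shown do not separate the loss of the ring from the change in the chain, so neither can be credited with the loss. From the compounds shown here alone, how an unbranched chain ending in a primary amine, or a benzyl group on the distal amine, would read remains open.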